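Working notes: benzyl to tetrahydroquinolinyl, cytotoxicity

The compounds below may be only part of what the source reports. "The series", "measured", "known", "first", "only" and "open" are said of these compounds alone.

Measured so far:
compound 1 `COc1ccc2[nH]c(C(=O)N3CC(=O)N(Cc4ccccc4)[C@@H](CCc4ccccc4)C3)cc2c1`: > 30000 nM
compound 2 `Cc1ccc2[nH]c(C(=O)N3CC(=O)N(Cc4ccccc4)[C@@H](CN4CCC5(CCC5)CC4)C3)cc2c1`: 7800 nM

In an ADME assay on Vero cells (Chlorocebus sabaeus) for cytotoxicity, with a stated time of 7 days (a lower number here means that less compound is tolerated, a higher number that more compound is tolerated), compound 1 returns only a limit, > 30000 nM, and not a number. That reading is the limit of > 30000 nM in this assay, at which 1 of the 2 values shown sits. Compound 2 gives 7800 nM in this assay. Within the data shown here, compound 2 differs from compound 1 in more than one place, so the two values show only that compound 2 returns a number where compound 1 does not.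

Compound 3 `COc1ccc2[nH]c(C(=O)N3CC(=O)N(Cc4ccccc4)[C@@H](CN4CCCc5ccccc54)C3)cc2c1` differs from compound 1 by 1,2,3,4-tetrahydroquinolin-1-yl in place of benzyl on a saturated chain carbon bound to a saturated ring carbon. Among the measured compounds shown here, no pair differing in one place has been measured, so the size of this kind of step in this assay is not yet known from the series itself. The expectation is a step toward less compound tolerated, of a size beyond the scatter but not large: the expected step is an at least 2.0-fold lower number from compound 1 to compound 3 (0.30 log units; that floor lies within the scatter). For compound 3 the estimate in this assay is 15000 nM, with a range from 5000 nM to 30000 nM.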

Compound 3, half-maximal cytotoxic concentration: > 100000 nM
Compound 3 was reported as a limit; the forecaster's own chance of this, stated with the estimate: 35%; at least 6.6-fold (0.82 log units) between middle value and limit.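

Among these compounds, compound 1 and compound 3 both return only limits in this assay, not numbers, so no step between them can be read. The compounds shown leave open how large any shift in this assay is when 1,2,3,4-tetrahydroquinolin-1-yl replaces benzyl.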